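This account rests on a few compounds, and the source may have more. Where it says the series, first, only, none or still open, it means among the compounds named here.

Of the compounds shown here, three sharing one core have been measured so far. In a functional assay on CCRF-CEM cells (Homo sapiens) for antiproliferative activity, read by MTT assay, with a stated time of 24 h, tested at 100 uM (on this read-out higher numbers stand for a weaker effect at the one concentration tested and lower numbers for a stronger effect), compound 1 `OC(CCn1nc2c(Br)c(Br)c(Br)c(Br)c2n1)c1cccc(Br)c1` gives 0%, and compound 2 `OC(CCn1nc2c(Br)c(Br)c(Br)c(Br)c2n1)c1ccc(F)cc1` gives 0%. Going by the values given here, the only single-point step between measured compounds is no change at the digits printed from compound 1 to compound 2 (within the scatter), and it concerns a different part of the chain from the one now being changed. Compound 3 `C[C@@H](O)CCn1nc2c(Br)c(Br)c(Br)c(Br)c2n1` gives 36%, the highest of the three numbers, and its gap to compound 1 and to compound 2 lies beyond the scatter. The unmeasured compound 4 `OCC(O)Cn1nc2c(Br)c(Br)c(Br)c(Br)c2n1` differs from compound 3 by 1,2-dihydroxyethyl in place of 2-hydroxypropyl on a saturated chain carbon bound to an aromatic nitrogen. Among the compounds with values here, no measured step touches this part of the molecule, so the expectation rests only on compound 3 and its value 36%. The step from compound 3 to compound 4 is expected to be a number 8 percentage points lower from compound 3 to compound 4 (within the scatter), small in either direction. Compound 4 is therefore estimated at 28%, within a range from 0% to 60%.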

Compound 4, a percentage reported as activity, at one concentration (the size of the read-out at that concentration, not a potency): 8%
For compound 4 the middle estimate is 20 percentage points above the measured one, within the range that was stated.
By their numbers in this assay, from the lowest: compounds 1, 2 and 4 (each within the scatter of the next); then compound 3.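

This position is sensitive to a small edit. In this assay putting 1,2-dihydroxyethyl in place of 2-hydroxypropyl gives a number 28 percentage points lower from compound 3 to compound 4 (beyond the scatter) and so a stronger effect at the one concentration tested, although both groups have 4 heavy atoms; the earlier step, from 3-bromophenyl to 4-fluorophenyl, moved nothing beyond the scatter. The data offer no measured explanation for this shift.

As far as these compounds go, whether the change follows the added hydroxyl or the lost defined stereocentre stays open, as the two come together here. From the compounds shown here alone, how an amine or a carboxylic acid would read on this chain is also open.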